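This account rests on a few compounds, and the source may have more. Where it says the series, first, only, none or still open, it means among the compounds named here.

Measured compounds in an assay on isolated protein for inhibition of Calpain-1 catalytic subunit (Sus scrofa), read by FRET; a higher number here means a weaker inhibitor, a lower number a stronger inhibitor:
- compound 1 `O=C(O)/C(S)=C/c1ccc(Br)cc1` gives 1500 nM
- compound 2 `O=C(O)/C(S)=C/c1c[nH]c2c(F)cccc12` gives 120 nM
- compound 3 `O=C(O)/C(S)=C/c1c[nH]c2cc(F)ccc12` gives 10 nM

All three share the same acid-bearing thiol-alkene side chain, differing only in the aromatic part carried on the alkene. Compound 1 carries a single bromo-substituted ring; compound 2 and compound 3 carry a fused two-ring system with a fluoro at different places. Among the three numbers, compound 3 stands lowest in this assay, well beyond the scatter from both compound 2 and compound 1, with compound 2 the nearer of the two and compound 1 the furthest.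

Compound 4 `O=C(O)/C(S)=C/c1c[nH]c2cc(I)ccc12` is not yet measured. It differs from compound 3 in one place: iodo in place of fluoro on an aromatic carbon. For the measured compounds named here, no measured pair here shows the same kind of exchange, so its effect cannot be read from the series. With nothing to point either way, the expectation is a step from compound 3 to compound 4 that stays within the scatter, or at most a small shift in either direction, with a slight lean toward a higher number given the larger group entering.

For compound 4 the estimated value in this assay is 18 nM, with a range from 5 nM to 70 nM, corresponding to an expected step of a 1.8-fold higher number from compound 3 to compound 4 (0.26 log units; within the scatter).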

Compound 4, half-maximal inhibitory concentration: 170 nM
Estimate against measurement, compound 4: 9.4-fold (0.98 log units) below; measured number outside the range, above it.
By their numbers in this assay, from the lowest: compound 3; then compounds 2 and 4 (each within the scatter of the next); then compound 1.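

In this assay, iodo in place of fluoro on this aromatic carbon, meta to a fused ring and para to a fused ring, gives a 17-fold higher number from compound 3 to compound 4 (1.23 log units; beyond the scatter) and so shows that this position is sensitive to which halogen it carries. For the compounds shown here, this is the first single-place step available, and it shows that a change of one heavy atom here can move the number well beyond the scatter, with no ring, hydrogen-bond donor, hydrogen-bond acceptor or net charge entering or leaving. No measurement at hand bears on the reason for this step, which therefore stands as an observation without an assigned cause.

Going by these compounds, with only fluoro and iodo compared at this carbon, it remains open whether chloro would fall nearer compound 3 or nearer compound 4, and whether a compound with hydrogen, a methoxy group or an amine there would retain the low number of compound 3. On these data alone, it also remains open whether the same exchange of fluoro for iodo would give a step of similar size on the other carbons of the six-membered ring.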